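Trimming a Methyl from a Serotonin Receptor Ligand

The source may report more compounds than this note shows. Statements on the series, on what has been measured and on what is new or still open speak of the compounds shown alone.

Of the compounds shown here, two have been measured so far. Compound 1 `CC(=O)Nc1ccc([C@H](C)NCC2CCN(CCCc3c[nH]c4ccc(-n5cnnc5)cc34)CC2)cc1` and compound 2 `CC(C)=CCN(C)C1CCN(CCCc2c[nH]c3ccc(-n4cnnc4)cc23)CC1` share the same core and were both tested in an assay on CHO cells for displacement of a labelled ligand from 5-hydroxytryptamine receptor 1B (Homo sapiens); on this read-out higher numbers stand for weaker inhibition and lower numbers for stronger inhibition. In this assay compound 1 gives 9.3 nM, and compound 2 gives 41 nM. Of these two numbers, compound 1 has the lower one, and its gap to compound 2 lies beyond the usual scatter of repeated measurements. For the measured compounds named here, no pair of measured compounds differs in only one place, so there is no measured single step to guide the next move.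

Compound 3 `CC(=O)Nc1ccc(CNCC2CCN(CCCc3c[nH]c4ccc(-n5cnnc5)cc34)CC2)cc1` differs from compound 1 in one spot: hydrogen in place of methyl on a saturated chain carbon bound to an amine nitrogen and an aromatic carbon. Everything else in the molecule stays the same, so the comparison rests on this one small change.

Going by the values given here, with no measured step of this kind available, the size of the step is uncertain. Removing a single methyl is expected to move this assay only modestly, with compound 3 expected to give a slightly higher number than compound 1, an estimated step of a 1.7-fold higher number from compound 1 to compound 3 (0.24 log units; within the scatter). Compound 3 is therefore expected to show about 16 nM in this assay, within a likely range from 5 nM to 50 nM.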

Compound 3, half-maximal inhibitory concentration: 8.9 nM
The estimate for compound 3 lay 1.8-fold (0.25 log units) above the measured number; the range from low to high includes it.
By their numbers in this assay, from the lowest: compounds 3 and 1 (each within the scatter of the next); then compound 2.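

For the compounds shown here, the step of a 1.0-fold lower number from compound 1 to compound 3 (0.02 log units; within the scatter) is the first measured single change, and in this assay it leaves compound 1 and compound 3 indistinguishable. On a saturated chain carbon bound to an amine nitrogen and an aromatic carbon, the methyl can therefore give way to hydrogen, turning 1-(4-acetamidophenyl)ethyl into 4-acetamidobenzyl, with no reading beyond the usual scatter; this also removes the defined handedness that compound 1 carries at that carbon, leaving a simpler structure with one heavy atom fewer. The measurements at hand offer nothing that explains why this pair reads alike.

On these data alone, this one pair shows only that hydrogen and methyl read alike at this carbon, so it remains open whether a larger group there, such as an ethyl or a hydroxymethyl group, would also fit within the scatter or would shift the number. Also open, as far as these compounds go, is how the mirror-image form of compound 1 would read, and whether the match between compound 1 and compound 3 would hold on any other receptor.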